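Adding Chloro to the Benzylsulfanyl Arm: Compound 3 to Compound 4

The source may hold more compounds than are shown below. What is called first, only, known or untested is meant among the compounds shown, and "the series" means these compounds.

The measured compounds and their values:

Compound 1 `COc1ccc(C2N=C(SCc3ccc(F)cc3)NC(C)=C2C(=O)Nc2ccc(F)cc2)cc1OC` gives 3.6%
Compound 2 `CC1=C(C(=O)Nc2ccc(F)cc2)C(c2ccc([N+](=O)[O-])cc2)N=C(SCc2cccc(Cl)c2)N1` gives 2.1%
Compound 3 `CC1=C(C(=O)Nc2ccc([N+](=O)[O-])cc2)C(c2ccc(Br)cc2)N=C(SCc2ccccc2)N1` gives 2.1%

All three numbers come from a functional assay on the whole organism (artery, strain albino) with Rattus norvegicus as the target, with a stated time of 15 min, at a dose of 10 mg/kg by the oral route; a lower number here means less inhibition, a higher number more inhibition at the dose given (going by the name of the read-out). The three compounds share a common core and differ in the groups hung on it. In this assay compound 3 stands level with compound 2 at the digits shown, and the number for compound 1 differs from compound 3 only within the usual scatter of repeated measurements. In plain terms, none of the three can be told apart on these data: each shows little inhibition at the dose given.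

Compound 4 `CC1=C(C(=O)Nc2ccc([N+](=O)[O-])cc2)C(c2ccc(Br)cc2)N=C(SCc2ccccc2Cl)N1` has not yet been measured. It differs from compound 3 in one place:

chloro in place of hydrogen on an aromatic carbon

Going by the values given here, no pair among the measured compounds differs by exactly one such change, so there is no earlier step of this kind to lean on. Given that the three measured values sit together within the scatter, the step from compound 3 to compound 4 is expected to be small, a number 0.9 percentage points higher from compound 3 to compound 4 (within the scatter), with no direction beyond the scatter. Compound 4 is therefore estimated at 3%, with a range from 0% to 12%.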

Compound 4, a percentage reported as inhibition, in the whole organism at one dose (the size of the read-out at that dose, not a potency): 1.5%
Compound 4: the middle estimate sits 1.5 percentage points above what was measured; the measured number falls inside the stated range.
By their numbers in this assay, from the lowest: compounds 4, 2, 3 and 1 (each within the scatter of the next).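

In this assay, going by these compounds alone, this pair gives the first reading of a single change, and the step is a number 0.6 percentage points lower from compound 3 to compound 4 (within the scatter). Chloro on an aromatic carbon of the benzyl ring, ortho to a large group, therefore gives a number that cannot be told apart from that of the parent with hydrogen there, so turning benzylsulfanyl into (2-chlorobenzyl)sulfanyl leaves this whole-animal read-out where it was, at a low level of inhibition. The earlier compounds differ from one another in more than one place and could not show this, and no measurement at hand explains the result.

One step at one dose says little about this arm as a whole, since a number this close to the floor of the read-out leaves little room to see a further fall. From the compounds shown here alone, it remains open whether a different group at the same place, such as an amine or a carboxylic acid, or a longer chain between the sulfur and the ring, would move the number beyond the scatter.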